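Opening the Cyclopropane: Compound 1 to Compound 4

The source may hold more compounds than are shown below. What is called first, only, known or untested is meant among the compounds shown, and "the series" means these compounds.

Measured compounds in an assay on NIH3T3 cells for binding affinity to melatonin receptor type 1B (Homo sapiens); a higher number here means a weaker inhibitor, a lower number a stronger inhibitor:
- compound 1 `CCC(=O)NC[C@@H]1CC1c1cccc2oc(CCCCc3ccccc3)cc12`: 2.8 nM
- compound 2 `CC(C)C(=O)NC[C@@H]1CC1c1cccc2oc(CCCCc3ccccc3)cc12`: 54 nM
- compound 3 `O=C(NC[C@@H]1CC1c1cccc2oc(CCCCc3ccccc3)cc12)C1CC1`: 33 nM

Compound 1 gives the lowest number of the three. The step from it to compound 3 is a 12-fold higher number from compound 1 to compound 3 (1.07 log units; beyond the scatter), and the step to compound 2 is a 19-fold higher number from compound 1 to compound 2 (1.29 log units; beyond the scatter), both well beyond the scatter. Compound 2 and compound 3 differ by a 1.6-fold lower number from compound 2 to compound 3 (0.21 log units; within the scatter), which lies within the scatter.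

Compound 4 `CCCC(=O)NCCCc1cccc2oc(CCCCc3ccccc3)cc12` differs from compound 1 in one place: 3-((propylcarbonyl)amino)propyl in place of 2-((propanoylamino)methyl)cyclopropyl on an aromatic carbon. The three-membered ring disappears and the acyl group changes as well. The measured steps touch only the acyl group: the two changes at the carbonyl carbon, to isopropyl and to cyclopropyl, each cost a large amount. Going by the values given here, no measured step shows what removing the ring itself does, so the expectation leans on the pattern that departures from compound 1 have so far raised the number, with wide uncertainty. Compound 4 is expected to give 25 nM, within 4 nM to 160 nM. The expected step is an 8.9-fold higher number from compound 1 to compound 4 (0.95 log units; beyond the scatter).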

Compound 4, inhibition constant: 82 nM
For compound 4 the middle estimate is 3.3-fold (0.52 log units) below the measured one; the range from low to high includes it.
By their numbers in this assay, from the lowest: compound 1; then compounds 3, 2 and 4 (each within the scatter of the next, the first and the last beyond it).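

In this assay, going by these compounds alone, replacing 2-((propanoylamino)methyl)cyclopropyl with the open chain 3-((propylcarbonyl)amino)propyl gives a 29-fold higher number from compound 1 to compound 4 (1.47 log units; beyond the scatter), so a change reaching beyond the acyl end of the group, the only part varied in the earlier steps, also carries a large cost. The two groups match in their counts of heavy atoms, hydrogen-bond donors and acceptors, but the entering group has no ring and no defined stereocentre, so a large step occurs even with those counts unchanged. No measurement available here explains why the number rises.

The compounds shown leave open how much of this step belongs to losing the ring and how much to the altered acyl group, since both change together. They also leave open how an acetyl group or a urea in place of the propanoyl amide would behave on either the cyclopropyl or the open-chain linker.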